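The source may hold more compounds than are shown below. What is called first, only, known or untested is meant among the compounds shown, and "the series" means these compounds.

Compound 1 `O=C1NC[C@@H](c2c[nH]c3ccccc23)N[C@H]1c1c[nH]c2ccccc12` — > 10 ug/mL
Compound 2 `O=C1NC[C@@H](c2c[nH]c3cc(Br)ccc23)N[C@H]1c1c[nH]c2ccccc12` — 7.1 ug/mL

Among the compounds with values here, in an ADME assay on SK-MEL-2 cells (Homo sapiens) for cytotoxicity (on this read-out lower numbers stand for an effect already at smaller amounts and higher numbers for an effect only at larger amounts of compound), compound 1 reaches only a limit of the assay, > 10 ug/mL, which is the sole number known for it. Compound 2 gives 7.1 ug/mL in this assay. Within the data shown here, the one measured step that bears on the change, an at least 1.4-fold lower number from compound 1 to compound 2 (0.14 log units; that floor lies within the scatter), rests on the limit of > 10 ug/mL in this assay, at which 1 of the 2 values shown sits, and sits within the scatter. Compound 3 `O=C1NC[C@@H](c2c[nH]c3ccccc23)N[C@H]1c1c[nH]c2cc(Br)ccc12` carries a like change: bromo in place of hydrogen on an aromatic carbon. Compound 3 is therefore expected to give about 7 ug/mL, between 4 ug/mL and 15 ug/mL, an estimated step of an at least 1.4-fold lower number from compound 1 to compound 3 (0.15 log units; that floor lies within the scatter) that is not expected to exceed the scatter.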

Compound 3, concentration for half-maximal effect: > 10 ug/mL
Compound 3: no number, only a limit; the forecaster's own chance of this, stated with the estimate: 40%; middle value at least 1.4-fold (0.15 log units) away from the limit.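

Compound 1 and compound 3 both rest at a limit of the assay rather than a number, so no step between them can be read: the limit of > 10 ug/mL in this assay, at which 2 of the 3 values shown sit.

Left open is whether bromo in place of hydrogen changes the result for compound 3 in this assay at all, and if so by how much.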